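Replacing hydrogen with a hydroxyethyl amide on the core

A few compounds are considered here, and "the series" means these few. Any claim that something is new, unique, unknown or untested is made for them only; others in the source may bear on it.

Measured compounds:
compound 1 `Cc1ccc2nc(Cn3c(=O)n(C4CC4)c4ccncc43)c(CCCCO)n2c1`: > 100000 nM
compound 2 `O=c1n(Cc2nc3ccc(Cl)cn3c2CCCCO)c2cnccc2n1C1CC1`: > 100000 nM
compound 3 `O=c1n(Cc2cn3ccc(Cl)cc3n2)c2cnccc2n1C1CC1`: 22300 nM

In an ADME assay on HEp-2 cells (Homo sapiens) for cytotoxicity, read by CCK-8 assay, with a stated time of 6 days (a higher number here means that more compound is tolerated, a lower number that less compound is tolerated), compound 1 gives > 100000 nM, a limit of the assay rather than a number. Compound 2 likewise gives > 100000 nM, again only a limit. Among the measured compounds shown here, compound 3 gives 22300 nM, the single plain number among the three, so it stands alone with nothing to be ranked against. The step that the two limits leave unreadable from compound 1 to compound 2 stays unreadable due to the limit of > 100000 nM in this assay, at which 2 of the 3 values shown sit.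

Compound 4 `O=C(NCCO)c1c(Cn2c(=O)n(C3CC3)c3ccncc32)nc2cc(Cl)ccn12` differs from compound 3 by (2-hydroxyethyl)carbamoyl in place of hydrogen on an aromatic carbon. For the measured compounds named here, no measured step covers this change, so its size is open. Compound 4 is expected at 60000 nM, within 20000 nM to 150000 nM. That estimate means a step of a 2.7-fold higher number from compound 3 to compound 4 (0.43 log units; beyond the scatter) and carries a real chance of ending as a limit.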

Compound 4, half-maximal cytotoxic concentration: > 100000 nM
Compound 4: a limit, no number (the forecaster's own chance of this, stated with the estimate: 40%); middle value at least 1.6-fold (0.22 log units) away from the limit.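

Among the compounds shown here, putting (2-hydroxyethyl)carbamoyl in place of hydrogen on this aromatic carbon of the five-membered ring gives the first readable step in this assay: an at least 4.4-fold higher number from compound 3 to compound 4 (0.65 log units; beyond the scatter). This shows that the shared core tolerates a large group here with more compound tolerated, not less. How far the step really reaches cannot be read, due to this ceiling: the limit of > 100000 nM in this assay, at which 3 of the 4 values shown sit.

As far as these compounds go, whether a simple amine, a carboxylic acid or a longer chain at this carbon would give a similar step stays open. The compounds shown also do not separate the amide from its hydroxyethyl end.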